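Swapping a chlorine for two fluorines on a benzyl arm

The source may report more compounds than this note shows. Statements on the series, on what has been measured and on what is new or still open speak of the compounds shown alone.

Measured compounds:
compound 1, `O=C(O)c1ccccc1-c1ccc(CCc2ncc(Cc3ccccc3Cl)[nH]2)cc1`, 292 nM
compound 2, `CCCCc1cnc(C(CC)Cc2ccc(-c3ccccc3C(=O)O)cc2)[nH]1`, 2720 nM

Both compounds were tested in an in vitro functional assay on cells for agonist activity at Bombesin receptor subtype-3 (Homo sapiens), read by luminescence and calcium flux; on this read-out higher numbers stand for an effect only at larger amounts of compound and lower numbers for an effect already at smaller amounts. Compound 1 gives 292 nM, the lower of the two numbers, meaning that it acts at smaller amounts than compound 2. Compound 2 gives 2720 nM; the gap between these two values lies beyond the usual scatter, so compound 1 is the more potent of the pair. The two compounds differ in more than one place, so nothing more can be read from the pair than what its two values show.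

Compound 3, `O=C(O)c1ccccc1-c1ccc(CCc2ncc(Cc3cccc(F)c3F)[nH]2)cc1`, has not yet been measured. It differs from compound 1 in a single place: 2,3-difluorophenyl in place of 2-chlorophenyl on a saturated chain carbon bound to an aromatic carbon. The shared core, the chain and the acid-bearing ring are kept unchanged.

Going by the values given here, no measured pair isolates this change, so the expectation rests only on compound 1. A small shift toward a higher number, within or just beyond the scatter, is expected, estimated as a 1.7-fold higher number from compound 1 to compound 3 (0.23 log units; within the scatter). For compound 3 the expected value in this assay is 500 nM, with a likely range from 150 nM to 1700 nM.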

Compound 3, half-maximal effective concentration: 87 nM
Estimate against measurement, compound 3: 5.7-fold (0.76 log units) above; measured number outside the range, below it.
By their numbers in this assay, from the lowest: compound 3; then compound 1; then compound 2.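

The benzyl arm turns out to be sensitive to a small edit: in this assay, putting 2,3-difluorophenyl in place of 2-chlorophenyl on a saturated chain carbon bound to an aromatic carbon gives a 3.4-fold lower number from compound 1 to compound 3 (0.53 log units; beyond the scatter), a step beyond the usual scatter. The pair of compounds 1 and 2 could not show this, since those two differ in more than one place, whereas here the shared core, the chain and the acid-bearing ring stay the same and only the substituents on this one ring change. Nothing given here explains why this swap lowers the number, so the step stands as an observation only.

Going by these compounds, the step exchanges one chlorine for two fluorines at once, so it stays open whether both fluorines are needed, or whether the loss of the chlorine alone accounts for the change; a benzyl arm with a single fluorine, or a plain benzyl arm, would help separate these possibilities. Also open, on these data alone, is how this arm would respond to other groups on the same ring, such as a methoxy or a trifluoromethyl group.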